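Replacing the 4-chlorophenyl group of compound 2

This account rests on a few compounds, and the source may have more. Where it says the series, first, only, none or still open, it means among the compounds named here.

Measured in a functional assay on NCI-H460 cells (Homo sapiens) for inhibition, read by MTT assay, with a stated time of 72 h (on this read-out higher numbers stand for weaker inhibition and lower numbers for stronger inhibition), so far:
compound 1 `COc1cc(NC(C)CCCNC(=O)Nc2ccc(Br)cc2)c2ncccc2c1` gives 30000 nM
compound 2 `COc1cc(NC(C)CCCNC(=O)Nc2ccc(Cl)cc2)c2ncccc2c1` gives 34000 nM

For the measured compounds named here, compound 2 at 34000 nM lies within the scatter of compound 1, its only measured neighbour. The next compound is compound 3 `COc1cc(NC(C)CCCNC(=O)NNC(=O)Nc2cccc(Cl)c2)c2ncccc2c1`, in which ((3-chlorophenyl)carbamoyl)amino stands in place of 4-chlorophenyl on an amide-type nitrogen (((3-chlorophenyl)carbamoyl)amino in place of 4-chlorophenyl on an amide-type nitrogen). Going by the values given here, the only measured step is a 1.1-fold higher number from compound 1 to compound 2 (0.05 log units; within the scatter) and it covers just chloro in place of bromo on an aromatic carbon. Among the compounds with values here, no measured step shows what this larger change does, so neither direction can be favoured with confidence. An expected step of a 1.4-fold lower number from compound 2 to compound 3 (0.13 log units; within the scatter) is therefore only a modest estimate, with no clear shift beyond the scatter anticipated. Compound 3 is estimated at 25000 nM in this assay (expected range 7000 nM to 80000 nM).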

Compound 3, half-maximal inhibitory concentration: 32000 nM
Compound 3: the middle estimate sits 1.3-fold (0.11 log units) below what was measured, within the range that was stated.
By their numbers in this assay, from the lowest: compounds 1, 3 and 2 (each within the scatter of the next).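

In this assay, ((3-chlorophenyl)carbamoyl)amino in place of 4-chlorophenyl on an amide-type nitrogen gives a 1.1-fold lower number from compound 2 to compound 3 (0.03 log units; within the scatter), and the same group in place of 4-bromophenyl gives a 1.1-fold higher number from compound 1 to compound 3 (0.03 log units; within the scatter). Earlier, this end of the molecule had been tested only by exchanging one halogen for another, whereas this much larger replacement also leaves the number within the scatter. No measurement available here accounts for this result.

As far as these compounds go, compound 3 alters both the length of the group and the place of the chlorine on the ring, so the share of each change stays open. From the compounds shown here alone, it also remains open whether a different group on that ring, such as an amine or a carboxylic acid, would move the number beyond the scatter.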